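Swapping the amide substituent in a bradykinin B1 antagonist

The compounds below may be only part of what the source reports. "The series", "measured", "known", "first", "only" and "open" are said of these compounds alone.

In an in vitro functional assay on cells for antagonist activity at B1 bradykinin receptor (Homo sapiens), read by luminescence and calcium flux, with a stated time of 2 h (a lower number here means a stronger inhibitor, a higher number a weaker inhibitor), compound 1 `Cc1ccc(S(=O)(=O)N2C=CNC(=O)[C@H]2CC(=O)NC2CCNc3ccccc32)cc1` gives 21.6 nM, and compound 2 `Cc1ccc(S(=O)(=O)N2C=CNC(=O)[C@H]2CC(=O)N[C@@H]2CCC(=O)c3ccccc32)cc1` gives 40.8 nM; the two numbers lie within the scatter of each other, so neither can be called more potent. Compound 3 `Cc1ccc(S(=O)(=O)N2C=CNC(=O)[C@H]2CC(=O)N[C@H]2CCN(C)CC2(C)C)cc1` is a new compound, untested in this assay. It differs from compound 1 by a group of 9 heavy atoms (8 carbon, 1 nitrogen; one six-membered non-aromatic ring with 1 hetero atom) in place of a group of 10 heavy atoms (9 carbon, 1 nitrogen; one six-membered non-aromatic ring with 1 hetero atom, one six-membered aromatic ring of carbon only), on an amide-type nitrogen. Within the data shown here, no measured pair shows such a change, so the step is uncertain; a modest weakening is expected, as a 3.0-fold higher number from compound 1 to compound 3 (0.48 log units; beyond the scatter). For compound 3 the estimate in this assay is 65 nM, with a range from 15 nM to 300 nM.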

Compound 3, half-maximal inhibitory concentration: 0.42 nM
Beside the measured number, compound 3's estimate is 150-fold (2.19 log units) above it, outside the stated range (below it).
By their numbers in this assay, from the lowest: compound 3; then compounds 1 and 2 (each within the scatter of the next).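

On the amide-type nitrogen, trading the group with a six-membered aromatic ring for one with only a six-membered non-aromatic ring gives a 51-fold lower number from compound 1 to compound 3 (1.71 log units; beyond the scatter) in this assay, a large gain in potency. Among these compounds, compound 1 and compound 2 lie within the scatter of each other, so only this step shows how strongly potency responds to the group at this position, and that the aromatic ring is not needed here. Nothing measured here explains the gain. As far as these compounds go, it remains open which part of the new group carries the gain, and whether an open carbon chain or a ring with oxygen in place of its nitrogen would do the same.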